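Free hydroxy in place of methoxy: cytotoxicity notes

This account rests on a few compounds, and the source may have more. Where it says the series, first, only, none or still open, it means among the compounds named here.

Compound 1 `COc1cc(/C=N/NC(=O)c2ccncc2)cc(OC)c1O`, compound 2 `COc1cc(/C=N/N(C)c2nc3ccccc3s2)cc(OC)c1O` and compound 3 `COc1cc(/C=N/N(C)c2nc3ccccc3s2)cc(OC)c1OC` have been measured in a functional assay on cells (Mus musculus) for cytotoxicity, read by MTT assay, with a stated time of 24 h, tested at 1 uM; a lower number here means a weaker effect, a higher number a stronger effect of the compound at the concentration tested. Compound 1 gives 34%, compound 2 gives 107% and compound 3 gives 7%. Compound 3 and compound 2 differ in one place, (hydrogen in place of methyl on an oxygen on an aromatic ring), and this change gives a number 100 percentage points higher from compound 3 to compound 2 (beyond the scatter). The difference between the core of compound 1 and the core of compound 3 is not broken down here. Compound 4 `COc1cc(/C=N/NC(=O)c2ccncc2)cc(O)c1O` is not yet measured. It differs from compound 1 by the same change, (hydrogen in place of methyl on an oxygen on an aromatic ring). Among the compounds with values here, only one precedent exists, and it sits on the other core, so the size of the step is uncertain. In this assay compound 4 is expected to give 65%, estimated between 25% and 110%. That estimate is expected to mean a number 31 percentage points higher from compound 1 to compound 4 (beyond the scatter). The expectation of a rise rests on the earlier step of a number 100 percentage points higher from compound 3 to compound 2 (beyond the scatter).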

Compound 4, a percentage reported as activity, at one concentration (the size of the read-out at that concentration, not a potency): 41%
The estimate for compound 4 lay 24 percentage points above the measured number; the range from low to high includes it.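

In this assay, methoxy to hydroxy on the core of compound 1 gives a number 7 percentage points higher from compound 1 to compound 4 (within the scatter). Set beside the earlier step, the same change does not carry over at the same size from one core to the other: the same change on two cores in this assay, a number 100 percentage points higher (beyond the scatter) from compound 3 to compound 2 and a number 7 percentage points higher (within the scatter) from compound 1 to compound 4, 93 percentage points apart, beyond the scatter of two such steps

The large step seen with compound 2 therefore cannot be assumed on the core of compound 1, but two pairs do not show which part of the cores accounts for the gap, and they give no rule for any further core.

As far as these compounds go, what an amine in place of the hydroxy, or an ethyl group in place of the methyl on that oxygen, would do on either core stays open. Whether the gap between the two cores would hold for those groups is open as well.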